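Series notes: oxadiazole side-chain variation at the amine-bearing carbon

The source may report more compounds than this note shows. Statements on the series, on what has been measured and on what is new or still open speak of the compounds shown alone.

Measured so far:
compound 1 `CCCCCCCCCCc1ccc(-c2noc(CN)n2)cc1` 62%
compound 2 `CCCCCCCCCCc1ccc(-c2noc(-c3cccc(CN)c3)n2)cc1` 2%
compound 3 `CCCCCCCCCCc1ccc(-c2noc([C@@H](N)CCCCN)n2)cc1` 43%

In an assay on HeLa cells for inhibition of sphingosine-1-phosphate transporter SPNS2 (Mus musculus), read by LC-MS, tested at 2 uM (a lower number here means less inhibition, a higher number more inhibition at the concentration tested (going by the name of the read-out)), compound 3 stands second highest of the three numbers, below compound 1 and well above compound 2. The step of a number 19 percentage points lower from compound 1 to compound 3 (beyond the scatter) is modest, while a number 60 percentage points lower from compound 1 to compound 2 (beyond the scatter) is large, and a number 41 percentage points higher from compound 2 to compound 3 (beyond the scatter) is large in the other direction.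

Compound 4 `CCCCCCCCCCc1ccc(-c2noc(CC(O)CN(C)C)n2)cc1` is not yet measured. Compared with compound 3 the change is 3-(dimethylamino)-2-hydroxypropyl in place of 1,5-diaminopentyl on an aromatic carbon.

Among the measured compounds shown here, two measured steps bear on this. Replacing the flexible aminomethyl chain by a ring-bearing group cost most of the inhibition in a number 60 percentage points lower from compound 1 to compound 2 (beyond the scatter), whereas lengthening the chain only cost a modest amount in a number 19 percentage points lower from compound 1 to compound 3 (beyond the scatter). Compound 4 keeps a chain with no ring and the same count of heavy atoms as the chain it replaces, so a step of the size seen between rings and chains is not expected; a step within the scatter or a modest drop in this assay is the more likely outcome, and the estimated step is a number 5 percentage points lower from compound 3 to compound 4 (within the scatter). For compound 4 the expected value in this assay is 38%, within a range from 15% to 62%.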

Compound 4, a percentage reported as inhibition, at one concentration (the size of the read-out at that concentration, not a potency): 61%
Beside the measured number, compound 4's estimate is 23 percentage points below it; low and high end bracket the measured number.
By their numbers in this assay, from the lowest: compound 2; then compound 3; then compounds 4 and 1 (each within the scatter of the next).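

In this assay, the change at this aromatic carbon gives a number 18 percentage points higher from compound 3 to compound 4 (beyond the scatter) even though both chains are without a ring and have 7 heavy atoms, so that count alone does not set the read-out here. Compound 4 also gives a number 59 percentage points higher from compound 2 to compound 4 (beyond the scatter) and a number 1 percentage points lower from compound 1 to compound 4 (within the scatter) in this assay, which shows that the larger 3-(dimethylamino)-2-hydroxypropyl chain can stand in this place with no step beyond the scatter from the small aminomethyl-bearing compound, unlike 1,5-diaminopentyl in compound 3. Nothing available explains why these two chains of equal size part in this way.

The hydroxyl and the dimethylamino group enter together in compound 4, so a chain carrying only the dimethylamino group or only the hydroxyl would be needed to tell which of them goes with the higher number. Also open, going by these compounds, are how a carboxylic acid or a longer dimethylamino-ending chain would behave at this carbon, and whether the read-out at a single concentration reflects any difference in potency between compound 1 and compound 4.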